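The source may report more compounds than this note shows. Statements on the series, on what has been measured and on what is new or still open speak of the compounds shown alone.

Measured compounds:
compound 1 `C[Se]/C(=N\C(=O)c1ccco1)NC(=O)c1ccco1` — 5940 nM
compound 2 `CS/C(=N\C(=O)c1ccco1)NC(=O)c1ccco1` — 8220 nM

In an ADME assay on MCF-10A cells (Homo sapiens) for cytotoxicity, read by MTT assay, with a stated time of 72 h (on this read-out lower numbers stand for stronger inhibition of growth and higher numbers for weaker inhibition of growth), compound 2 and compound 1 give numbers that lie within the scatter of each other: a 1.4-fold higher number from compound 1 to compound 2 (0.14 log units; within the scatter). Within the data shown here, that step, selenium-for-sulfur on the carbon with a double bond to nitrogen, is the only measured step that bears on compound 3 `O=C(/N=C(/NC(=O)c1ccco1)[Se]Cc1ccccc1)c1ccco1`, whose change from compound 2 is a group of 8 heavy atoms (7 carbon, 1 selenium; one six-membered aromatic ring of carbon only) in place of a group of 2 heavy atoms (1 carbon, 1 sulfur; no ring), on a carbon with a double bond to nitrogen. Among the measured compounds shown here, the benzyl-for-methyl part of the change has no measured counterpart in this set. Given that the sulfur-selenium swap showed no step beyond the scatter, a step of about a 1.4-fold lower number from compound 2 to compound 3 (0.14 log units; within the scatter) is expected, with a wide range. Compound 3 is estimated at 6000 nM (range 2500 nM to 15000 nM) in this assay.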

Compound 3, concentration for 50% growth inhibition: 8800 nM
Compound 3: the middle estimate sits 1.5-fold (0.17 log units) below what was measured, and the stated range covers the measured number.
By their numbers in this assay, from the lowest: compounds 1, 2 and 3 (each within the scatter of the next).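

In this assay, a group carrying a six-membered aromatic ring on the carbon with a double bond to nitrogen leaves the number within the scatter (a 1.1-fold higher number from compound 2 to compound 3 (0.03 log units; within the scatter)). Phenyl in place of hydrogen on the saturated chain carbon bound to selenium likewise gives no step beyond the scatter (a 1.5-fold higher number from compound 1 to compound 3 (0.17 log units; within the scatter)). Nothing available explains why these numbers stay so close.

Still open, from the compounds shown here alone, is whether a longer chain on selenium, or an amine or a carboxylic acid on the benzyl ring, would give a step beyond the scatter. Also open, going by these compounds, is how a benzyl group on sulfur would compare.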